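Cytotoxicity series: dichlorophenyl variant of compound 3

A few compounds are considered here, and "the series" means these few. Any claim that something is new, unique, unknown or untested is made for them only; others in the source may bear on it.

Measured compounds:
compound 3 `C=CCn1c(=O)/c(=C\c2cccc(F)c2)[nH]c(=O)/c1=C\c1ccccc1OC` — 6500 nM in a functional assay on MOLT-4 cells (Homo sapiens) for cytotoxicity, read by CCK-8 assay, with a stated time of 72 h; a lower number here means a stronger inhibitor, a higher number a weaker inhibitor
compound 1 `COc1ccccc1/C=c1/[nH]c(=O)/c(=C\c2ccccc2OC)n(C)c1=O` — "not determined" (no result reported) in this assay
compound 2 `COc1ccccc1/C=c1/[nH]c(=O)/c(=C\c2cccc(Cl)c2Cl)[nH]c1=O` — "not determined" (no result reported) in this assay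

Among the compounds with values here, compound 3 is the only member of the series with a number in this assay, where compound 3 gives 6500 nM; compound 1 and compound 2 have no result, so no step between measured compounds can be given. Compound 4 `C=CCn1c(=O)/c(=C\c2cccc(Cl)c2Cl)[nH]c(=O)/c1=C\c1ccccc1OC` differs from compound 3 by 2,3-dichlorophenyl in place of 3-fluorophenyl on a double-bonded chain carbon bound to an aromatic carbon. Within the data shown here, with no comparable step in hand, the direction of the change is open; a modest move toward stronger inhibition is expected, though one that may not exceed the scatter. For compound 4 in this assay the estimate is 4000 nM, with a range from 1500 nM to 12000 nM, meaning an expected step of a 1.6-fold lower number from compound 3 to compound 4 (0.21 log units; within the scatter).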

Compound 4, half-maximal inhibitory concentration: 1200 nM
Compound 4: middle estimate off by 3.3-fold (0.52 log units), on the high side; the whole stated range lies above it.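

In this assay, 2,3-dichlorophenyl in place of 3-fluorophenyl on a double-bonded chain carbon bound to an aromatic carbon gives the series' first readable step (a 5.4-fold lower number from compound 3 to compound 4 (0.73 log units; beyond the scatter)). The number at this position therefore depends on the aromatic group it carries, with a change that exceeds the usual scatter. Nothing at hand accounts for the size of this step.

On these data alone, whether a single chlorine would give a similar step remains open. So does the outcome with an amine or a carboxylic acid on that phenyl group.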